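Compound 1 and a swap at the sulfonyl group

The compounds below may be only part of what the source reports. "The series", "measured", "known", "first", "only" and "open" are said of these compounds alone.

Measured in a functional assay on DU-145 cells (Homo sapiens) for inhibition, read by trypan blue exclusion, with a stated time of 96 h; a lower number here means a stronger inhibitor of growth, a higher number a weaker inhibitor of growth:
Compound 1 `CN(C)c1ccc(/C=C(\C(=O)c2ccc(Cl)cc2)S(=O)(=O)c2ccc(Br)cc2)cc1`: > 100000 nM (a limit)
Compound 2 `Cc1cc(C)cc(/C=C(\C(=O)c2ccc(Cl)cc2)S(=O)(=O)c2ccc(Br)cc2)c1`: 10000 nM

Compound 1 gives > 100000 nM, and this is a limit of the assay and not a number. Its true position is therefore unknown, and any step away from it is uncertain in size.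

Compound 3 `CN(C)c1ccc(/C=C(/SCc2ccc(Cl)c(Cl)c2)C(=O)c2ccc(Cl)cc2)cc1` keeps the 4-(dimethylamino)phenyl group of compound 1 and changes another place: (3,4-dichlorobenzyl)sulfanyl in place of (4-bromophenyl)sulfonyl on a double-bonded chain carbon bound to a carbonyl carbon and a double-bonded chain carbon. The new group is (3,4-dichlorobenzyl)sulfanyl, on the double-bonded chain carbon bound to a carbonyl carbon and a double-bonded chain carbon.

For the measured compounds named here, only one measured step is available, an at least 10-fold lower number from compound 1 to compound 2 (1.00 log units; beyond the scatter). It replaced the group that compound 3 retains, so it bears on this change only indirectly. Going by the values given here, it shows that the series can move beyond the scatter, but no measured step covers the place altered here.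

A modest move to a lower number in this assay is therefore expected, although another limit reading remains possible. The expected size is an at least 2.5-fold lower number from compound 1 to compound 3 (0.39 log units; beyond the scatter). For compound 3 the estimated value is 40000 nM, with an expected range of 5000 nM to 100000 nM.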

Compound 3, concentration for 50% growth inhibition: 50000 nM
Estimate against measurement, compound 3: 1.3-fold (0.10 log units) below; measured number inside the range.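

The place on the double-bonded chain carbon bound to a carbonyl carbon and a double-bonded chain carbon is now shown to matter as well: with the 4-(dimethylamino)phenyl group kept, the swap to (3,4-dichlorobenzyl)sulfanyl gives a measured number in this assay, whereas the earlier step had changed only that 4-(dimethylamino)phenyl group. Compound 1 stands at > 100000 nM, which is a limit and not a number. The swap reads as an at least 2.0-fold lower number from compound 1 to compound 3 (0.30 log units; that floor lies within the scatter), a floor that lies within the scatter, and its true size stays unknown because one end of it rests on a limit: the limit of > 100000 nM in this assay, at which 1 of the 3 values shown sits.

The entering group differs from the leaving one in more than one respect, as it has no oxygen on the sulfur and carries a benzyl group with two chlorines, so the compounds shown do not separate these parts; a plain benzylsulfanyl or a (4-bromophenyl)sulfanyl group at this place would bear on that. Also open, on these data alone, is whether the swap would give a similar step on the 3,5-dimethylphenyl background of compound 2.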